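The source may hold more compounds than are shown below. What is called first, only, known or untested is meant among the compounds shown, and "the series" means these compounds.

Measured so far: compound 1 `Cc1ccc(C(=O)c2cc(Cl)ccc2Oc2cc(C)nc(Nc3ccc(C#N)cc3)n2)cc1` at 26600 nM; compound 2 `Cc1cc(C)cc(C(=O)c2cc(Cl)ccc2Oc2cc(C)nc(Nc3ccc(C#N)cc3)n2)c1` at 37100 nM; compound 3 `Cc1ccc(C(=O)c2cc(Cl)ccc2Oc2nc(Nc3ccc(C#N)cc3)ncc2C)cc1` at >= 830 nM, which is a limit of the assay rather than a number.

All three were tested in an ADME assay on MT4 cells (Homo sapiens) for cytotoxicity, read by MTT assay, with a stated time of 5 days; on this read-out higher numbers stand for lower toxicity in this test and lower numbers for higher toxicity in this test. In this assay compound 1 gives 26600 nM and compound 2 gives 37100 nM. The two differ by 3,5-dimethylphenyl in place of 4-methylphenyl on a carbonyl carbon, and that change made a 1.4-fold higher number from compound 1 to compound 2 (0.14 log units; within the scatter). For compound 3 this assay reports only a limit, >= 830 nM, which is the limit of >= 830 nM in this assay, at which 1 of the 3 values shown sits.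

Compound 4 `Cc1cc(C)cc(C(=O)c2cc(Cl)ccc2Oc2nc(Nc3ccc(C#N)cc3)ncc2C)c1` has not yet been measured. Among the measured compounds shown here, it differs from compound 3 by 3,5-dimethylphenyl in place of 4-methylphenyl on a carbonyl carbon, the same change as the one from compound 1 to compound 2. How the core of compound 3 differs from the core of compound 1 is not broken down here.

Because the earlier step was a 1.4-fold higher number from compound 1 to compound 2 (0.14 log units; within the scatter), the step from compound 3 to compound 4 is expected to be small, about a step that the limit leaves unreadable from compound 3 to compound 4. Compound 4 is therefore estimated at 1500 nM, with the result quite likely to come back as a limit again, as it did for compound 3.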

Compound 4, half-maximal cytotoxic concentration: 13400 nM
Compound 4: middle estimate off by 8.9-fold (0.95 log units), on the low side; measured number outside the range, above it.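

No size can be read for the change from compound 3 to compound 4. In this assay compound 3 gives >= 830 nM, which is a limit and not a number. The compounds shown leave open whether 3,5-dimethylphenyl in place of 4-methylphenyl on a carbonyl carbon shifts the number by a similar amount on the core of compound 3 and on the core of compound 1.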